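Moving the bromine from 4-bromophenyl to 3-bromophenyl

The source may report more compounds than this note shows. Statements on the series, on what has been measured and on what is new or still open speak of the compounds shown alone.

Measured in a functional assay on K562 cells (Homo sapiens) for inhibition; on this read-out higher numbers stand for weaker inhibition and lower numbers for stronger inhibition:
- compound 1 `CCOc1ccc(Br)cc1-c1cc(Nc2ccc(/C(C)=N\O)cc2)nc(N)n1` gives < 50 nM
- compound 2 `Nc1nc(Nc2ccc(Cl)cc2)cc(-c2cc(Cl)ccc2Cl)n1` gives < 100 nM
- compound 3 `Cc1ccc(Cl)cc1-c1cc(Nc2ccc(Br)cc2)nc(N)n1` gives 60 nM

Compound 1 has the entry < 50 nM, which is a limit and not a number. For compound 2, the entry < 100 nM is also a limit and not a number. Going by the values given here, compound 3, at 60 nM, therefore holds the only exact number among the three in this assay.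

The next compound, compound 4 `Cc1ccc(Cl)cc1-c1cc(Nc2cccc(Br)c2)nc(N)n1`, has the same atoms as compound 3, joined differently, with 3-bromophenyl in place of 4-bromophenyl on a nitrogen on an aromatic ring. Among the compounds with values here, no measured pair differs in a single place, so the data offer no direct guide to the size of this step. A modest move towards weaker inhibition is expected, though a result within the scatter would be no surprise. The expected change is a 2.2-fold higher number from compound 3 to compound 4 (0.34 log units; beyond the scatter), starting from compound 3 at 60 nM. For compound 4, the estimated value is 130 nM, with an expected range of 40 nM to 450 nM.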

Compound 4, half-maximal inhibitory concentration: 200 nM
Compound 4: the middle estimate sits 1.5-fold (0.19 log units) below what was measured; low and high end bracket the measured number.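

Going by these compounds alone, this is the first pair that differs in one place only, so the placing of the bromine on the ring carried by the nitrogen can now be read directly. In this assay, 3-bromophenyl in place of 4-bromophenyl gives a 3.3-fold higher number from compound 3 to compound 4 (0.52 log units; beyond the scatter) with no atom gained or lost, which shows that the placing alone moves this read-out towards weaker inhibition. Nothing shown here bears on why the placing of the bromine matters.

This single pair supports no rule for the other compounds shown, and it cannot be said whether moving the chlorine on the same ring of compound 2 would give a similar step. From the compounds shown here alone, it also remains open how an amine or a carboxylic acid in place of the bromine would behave at either place on that ring.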